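Chloro for methoxy on a weakly active series

The source may hold more compounds than are shown below. What is called first, only, known or untested is meant among the compounds shown, and "the series" means these compounds.

Measured in a functional assay on HT-29 cells (Homo sapiens) for inhibition, read by MTT assay, with a stated time of 48 h (on this read-out higher numbers stand for weaker inhibition and lower numbers for stronger inhibition), so far:
Compound 1 `COc1ccc(-n2c(SCC(=O)Nc3ccc(Cl)cc3)nnc2-c2cc(OC)c(OC)c(OC)c2)cc1` gives 58000 nM as its value
Compound 2 `COc1cc(-c2nnc(S)n2-c2ccc(N(C)C)cc2)cc(OC)c1OC` gives > 60000 nM as a limit of the assay, not a number
Compound 3 `COc1ccc(NC(=O)CSc2nnc(-c3cc(OC)c(OC)c(OC)c3)n2-c2ccc(N(C)C)cc2)cc1` gives 51400 nM as its value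

Only compound 3 and compound 1 give true numbers, and these two lie within the scatter of each other. The next change leads to compound 4 `COc1cc(-c2nnc(SCC(=O)Nc3ccc(Cl)cc3)n2-c2ccc(N(C)C)cc2)cc(OC)c1OC` and is chloro in place of methoxy on an aromatic carbon in all: chloro in place of methoxy on an aromatic carbon, para to a large group.

Within the data shown here, no measured step makes this exchange. The only one is an at least 1.1-fold lower number from compound 2 to compound 3 (0.06 log units; that floor lies within the scatter) and it concerns a different place, on the sulfur. Compound 1 also bears the (4-chlorophenyl)carbamoyl group and gives 58000 nM in this assay as its value, so nothing measured points to a large shift. The expected change is a 1.3-fold lower number from compound 3 to compound 4 (0.11 log units; within the scatter) and thus no step beyond the scatter. For compound 4 the estimated value is 40000 nM with an expected range from 10000 nM to 70000 nM in this assay.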

Compound 4, half-maximal inhibitory concentration: > 60000 nM
Compound 4 was reported as a limit; the forecaster's own chance of this, stated with the estimate: 20%; middle value at least 1.5-fold (0.17 log units) away from the limit.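

In this assay compound 4 gives > 60000 nM, a limit of the assay and not a number. Chloro in place of methoxy on an aromatic carbon, para to a large group, now has a measured pair of its own, and it gives an at least 1.1-fold higher number from compound 3 to compound 4 (0.06 log units; that floor lies within the scatter), so this exchange shows no step beyond the scatter. With the (4-chlorophenyl)carbamoyl group kept, dimethylamino in place of methoxy gives an at least 1.0-fold higher number from compound 1 to compound 4 (0.01 log units; that floor lies within the scatter), while the step from compound 2, which joins two limits, cannot be read.

From the compounds shown here alone, how far these steps truly reach stays open, because the readings stop at a ceiling: the limit of > 60000 nM in this assay, at which 2 of the 4 values shown sit. Also open, going by these compounds, is whether an amine or a carboxylic acid in place of the chloro of compound 4 would give a true number in this assay.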